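A few compounds are considered here, and "the series" means these few. Any claim that something is new, unique, unknown or untested is made for them only; others in the source may bear on it.

- Compound 1 `Cc1cc(C)cc(N2CCN(C(=O)c3oc(C)nc3-c3ccccc3)CC2)c1`: 34.5 nM
- Compound 2 `Cc1nc(-c2ccccc2)c(C(=O)N2CCN(c3ccc(Cl)c(Cl)c3)CC2)o1`: 124 nM

These two compounds were measured in a functional assay on HL-60 cells (Homo sapiens) for inhibition, read by MTT assay, with a stated time of 72 h; a lower number here means a stronger inhibitor, a higher number a weaker inhibitor. Compound 2, at 124 nM, has the higher of the two numbers, which makes it the weaker inhibitor of the pair.

The next compound, compound 3 `COc1cc(OC)cc(N2CCN(C(=O)c3oc(C)nc3-c3ccccc3)CC2)c1`, keeps the core of compound 2 and changes only the group on an amine nitrogen in a ring: 3,5-dimethoxyphenyl in place of 3,4-dichlorophenyl on an amine nitrogen in a ring.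

Within the data shown here, only one measured step bears on this change. It is a 3.6-fold higher number from compound 1 to compound 2 (0.56 log units; beyond the scatter), a modest step beyond the scatter, made at the same place when 3,4-dichlorophenyl replaced 3,5-dimethylphenyl. By name, the entering 3,5-dimethoxyphenyl resembles the group of compound 1 more closely than the group it replaces. A modest step towards a lower number is therefore expected, of about the size seen between the two measured compounds, though somewhat smaller. Among the measured compounds shown here, no measured compound carries this group, so the expectation rests on that single step and remains uncertain.

The estimated step is a 2.1-fold lower number from compound 2 to compound 3 (0.32 log units; beyond the scatter), towards stronger inhibition. For compound 3 the expected value is 60 nM, with an estimated range of 20 nM to 170 nM.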

Compound 3, half-maximal inhibitory concentration: 19.2 nM
For compound 3 the middle estimate is 3.1-fold (0.49 log units) above the measured one, and the stated range ends above it.
By their numbers in this assay, from the lowest: compounds 3 and 1 (each within the scatter of the next); then compound 2.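

In this assay, 3,5-dimethoxyphenyl in place of 3,4-dichlorophenyl on the ring nitrogen gives a 6.5-fold lower number from compound 2 to compound 3 (0.81 log units; beyond the scatter), a modest step beyond the scatter, so a second replacement of the 3,4-dichlorophenyl group now lies on the side of stronger inhibition. The step of a 1.8-fold lower number from compound 1 to compound 3 (0.25 log units; within the scatter) lies within the scatter, so in this assay the 3,5-dimethoxyphenyl and 3,5-dimethylphenyl groups cannot be told apart, although their substituents differ in kind. No measurement shown here explains why these groups behave as they do.

Compound 2 differs from compound 1 and compound 3 both in what its phenyl ring carries and in where those groups stand, so these three compounds cannot show which of the two differences matters. From the compounds shown here alone, a 3,5-dichlorophenyl group on the same ring nitrogen would separate them, while an unsubstituted phenyl group would show what the substituents contribute at all, and both remain open here.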